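Series notes: azide in place of the hydroxyethylamino side chain

The source may report more compounds than this note shows. Statements on the series, on what has been measured and on what is new or still open speak of the compounds shown alone.

Compound 2 `OCCNc1[nH]ccc2ncnc1-2` is the reference point for the present step. In a functional assay on EL4 cells (Mus musculus) for inhibition, tested at 100 uM (on this read-out lower numbers stand for less inhibition and higher numbers for more inhibition at the one concentration tested (going by the name of the read-out)), compound 2 reports only a limit, < 5%, and no number. The two neighbours with numbers frame it: compound 1 `CCCCCCNc1[nH]ccc2ncnc1-2` gives 100% in this assay, and compound 3 `CN(C)c1nccc2c1ncn2C1O[C@H](CO)[C@@H](O)[C@H]1O` gives 10% in this assay. Within the data shown here, the only measured step that differs in one place is a number at least 95 percentage points lower from compound 1 to compound 2 (beyond the scatter), so exchanging the longer chain for the short hydroxylated one takes the read-out from the top of the range down to the limit; on that step the lone piece of evidence is the limit of < 5% in this assay, at which 1 of the 3 values shown sits.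

Compound 4 `[N-]=[N+]=Nc1[nH]ccc2ncnc1-2` is not yet measured. It differs from compound 2 by azido in place of (2-hydroxyethyl)amino on an aromatic carbon. No measured step covers the loss of the chain to a small group with no hydrogen-bond donor, and the starting point is itself a limit, so the direction of any change cannot be read from the numbers shown. The expectation is that compound 4 stays near the bottom of the range, with a step of a number at least 5 percentage points higher from compound 2 to compound 4 (that floor lies within the scatter), not clearly beyond the scatter. Compound 4 is therefore estimated at 10% in this assay, within 0% to 35%.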

Compound 4, a percentage reported as inhibition, at one concentration (the size of the read-out at that concentration, not a potency): < 5%
Compound 4: a limit, no number (the forecaster's own chance of this, stated with the estimate: 45%); middle value at least 5 percentage points from the limit.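

In this assay, compound 2 and compound 4 each report only a limit and no number, so no step can be read between them: the limit of < 5% in this assay, at which 2 of the 4 values shown sit.

The compounds shown leave open whether azido and (2-hydroxyethyl)amino differ at all on the shared core, as neither compound gives a number that would show a difference.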